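Emax series: piperidine nitrogen substituent exchange

The source may report more compounds than this note shows. Statements on the series, on what has been measured and on what is new or still open speak of the compounds shown alone.

Measured compounds:
Compound 1 `CC(C)(C)OC(=O)N1CCC(O[C@H]2CC[C@H](Oc3ccc(S(C)(=O)=O)cc3F)CC2)CC1` — in a functional assay on isolated protein for agonist activity at Glucose-dependent insulinotropic receptor (Rattus norvegicus), read by HTRF and cAMP accumulation (a higher number here means a larger maximal response, a lower number a smaller maximal response), compound 1 gives 119%
Compound 2 `CC(C)(C)OC(=O)N1CCC(O[C@H]2CC[C@H](Oc3ccc(S(C)(=O)=O)c(F)c3)CC2)CC1` — in this assay compound 2 gives 109%
Compound 3 `CC(C)(C)OC(=O)N1CCC(O[C@H]2CC[C@H](Oc3cnc(S(C)(=O)=O)cn3)CC2)CC1` — in this assay compound 3 gives 110%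

All three measured values sit within the usual scatter of one another, so no ordering among them can be claimed. The value of compound 3 lies nearest to that of compound 2 and furthest from that of compound 1, both gaps being within the scatter; the set reads as uniformly full maximal response in this assay.

Compound 4 `CS(=O)(=O)c1cnc(O[C@H]2CC[C@H](OC3CCN(CC4(C(F)(F)F)CC4)CC3)CC2)cn1` differs from compound 3 in one place: (1-(trifluoromethyl)cyclopropyl)methyl in place of tert-butoxycarbonyl on an amine nitrogen in a ring. The shared core of compound 3 and compound 4 is otherwise unchanged. Within the data shown here, no step between measured compounds bears on this exchange at the amine nitrogen in a ring, so the expectation rests only on the flat picture across compounds 1, 2 and 3. For compound 4 the expected step of no change at the digits printed from compound 3 to compound 4 (within the scatter) is none beyond the scatter. Compound 4 is therefore estimated at 110% in this assay, with a range from 90% to 130%.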

Compound 4, largest response reached (Emax), in percent of the reference or control that the assay uses: 124%
For compound 4 the middle estimate is 14 percentage points below the measured one, and the stated range covers the measured number.
By their numbers in this assay, from the lowest: compounds 2, 3, 1 and 4 (each within the scatter of the next, the first and the last beyond it).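

Among these compounds, the amine nitrogen in a ring is the first place where a change moves the read-out: in this assay, (1-(trifluoromethyl)cyclopropyl)methyl in place of tert-butoxycarbonyl gives a number 14 percentage points higher from compound 3 to compound 4 (beyond the scatter), whereas compounds 1, 2 and 3 lie within the scatter of one another. The entering group has no hydrogen-bond acceptors and no double bond outside aromatic rings, so neither feature of tert-butoxycarbonyl is needed on this nitrogen for a full maximal response, at least on the shared core of compound 3 and compound 4. Nothing available here bears on why the maximal response shifts with this exchange.

On these data alone, whether the same exchange gives a similar step on the cores of compound 1 and compound 2 remains open. Also open, as far as these compounds go, is how a free secondary amine, an acetyl amide or a plain cyclopropylmethyl group on this nitrogen would compare.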